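This account rests on a few compounds, and the source may have more. Where it says the series, first, only, none or still open, it means among the compounds named here.

Compound 1 `C=CC(=O)N1CCCC(n2nc(-c3ccc(Oc4ccccc4)cc3)cc2C(=O)OCC)C1` and compound 3 `CCOC(=O)c1cc(-c2ccc(Oc3ccccc3)cc2)nn1C1CCCN(C(=O)CCl)C1` share one core and differ by chloromethyl in place of vinyl on a carbonyl carbon. In a functional assay on Rec1 cells (Homo sapiens) for inhibition, read by luminescence and CellTiter-Glo, with a stated time of 72 h (a lower number here means a stronger inhibitor, a higher number a weaker inhibitor), compound 1 gives 13800 nM, while compound 3 gives 400 nM, a change of a 35-fold lower number from compound 1 to compound 3 (1.54 log units; beyond the scatter). Compound 2 `C=CC(=O)Nc1cccc(Cn2nc(-c3ccc(Oc4ccccc4)cc3)cc2CO)c1` is built on a different core; the difference between the two cores is not broken down here. In this assay compound 2 gives 1300 nM. Compound 4 `O=C(CCl)Nc1cccc(Cn2nc(-c3ccc(Oc4ccccc4)cc3)cc2CO)c1` has not been measured and differs from compound 2 by chloromethyl in place of vinyl on a carbonyl carbon. This is the same kind of change as that from compound 1 to compound 3, though here the carbonyl carbon's other neighbour is an amide-type nitrogen rather than an amide-type nitrogen in a ring. The earlier step was a 35-fold lower number from compound 1 to compound 3 (1.54 log units; beyond the scatter), and compound 2 stands at 1300 nM. Going by the values given here, the expected step is a 12-fold lower number from compound 2 to compound 4 (1.07 log units; beyond the scatter) in this assay, drawn somewhat smaller than the earlier one, as only one example of this change has been measured. Compound 4 is estimated at 110 nM, between 25 nM and 500 nM.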

Compound 4, half-maximal inhibitory concentration: 400 nM
Compound 4: middle estimate off by 3.6-fold (0.56 log units), on the low side; the range from low to high includes it.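

In this assay, chloromethyl in place of vinyl on a carbonyl carbon again gives a lower number, with a 3.3-fold lower number from compound 2 to compound 4 (0.51 log units; beyond the scatter), so the direction of the change carries over from one core to the other. The size of the step does not carry over: the same change on two cores in this assay, a 35-fold lower number (1.54 log units; beyond the scatter) from compound 1 to compound 3 and a 3.3-fold lower number (0.51 log units; beyond the scatter) from compound 2 to compound 4, 11-fold (1.03 log units) apart, beyond the scatter of two such steps. These two pairs do not show why the size differs, and two examples cannot give a dependable size for the same change on a third core.

Going by these compounds, it remains open whether bromomethyl or plain methyl on the carbonyl carbon would follow the same direction on both cores. Also open, on these data alone, is which part of the cores goes with the larger step.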